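A few compounds are considered here, and "the series" means these few. Any claim that something is new, unique, unknown or untested is made for them only; others in the source may bear on it.

Measured so far:
Compound 1 `Cc1oc(-c2ccccc2Cl)nc1CN1CCC(C(=O)NCCCN2C[C@H](C)C[C@H](C)C2)CC1`: 16500 nM
Compound 2 `Cc1cccc(C)c1-c1nc(CN2CCC(C(=O)NCCCN3C[C@H](C)C[C@H](C)C3)CC2)c(C)o1`: 21000 nM

In an ADME assay on Huh7.5.1 cells (Homo sapiens) for cytotoxicity, read by ATP content, with a stated time of 48 h (on this read-out higher numbers stand for lower toxicity in this test and lower numbers for higher toxicity in this test), compound 2 gives 21000 nM. This lies within the scatter of the number for compound 1, so the two cannot be ranked on these data. Compound 3 `Cc1cc(C)cc(-c2nc(CN3CCC(C(=O)NCCCN4C[C@H](C)C[C@H](C)C4)CC3)c(C)o2)c1` has not yet been measured. It keeps the rest of compound 2 and alters only the aromatic group on the shared core: 3,5-dimethylphenyl in place of 2,6-dimethylphenyl on an aromatic carbon.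

Within the data shown here, only one measured step bears on this change. It concerns the same place on the core, and a 1.3-fold higher number from compound 1 to compound 2 (0.10 log units; within the scatter) stays within the scatter. Among the measured compounds shown here, that step swaps 2-chlorophenyl for 2,6-dimethylphenyl, so it offers only limited guidance, and no measured compound yet carries the 3,5-dimethylphenyl group. With that single small step as the guide, no shift beyond the scatter is expected in this assay, and no direction can be favoured.

The expected change is a 1.1-fold lower number from compound 2 to compound 3 (0.02 log units; within the scatter). For compound 3 the estimated value is 20000 nM, with an expected range of 10000 nM to 40000 nM.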

Compound 3, half-maximal cytotoxic concentration: 4050 nM
The estimate for compound 3 lay 4.9-fold (0.69 log units) above the measured number; measured number outside the range, below it.
By their numbers in this assay, from the lowest: compound 3; then compounds 1 and 2 (each within the scatter of the next).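

In this assay, the aromatic group on the shared core proves to be a place where this number can move: the step between compound 1 and compound 2 had stayed within the scatter, yet a 5.2-fold lower number from compound 2 to compound 3 (0.71 log units; beyond the scatter), a change that only joins the same atoms differently by replacing 2,6-dimethylphenyl with 3,5-dimethylphenyl. Among these compounds, the replacement of 2-chlorophenyl by 3,5-dimethylphenyl gives a step of similar character, a 4.1-fold lower number from compound 1 to compound 3 (0.61 log units; beyond the scatter), so compound 3 stands apart from both earlier compounds as the one with the lowest number, which means higher toxicity in this test. Nothing available here accounts for this difference between the two dimethylphenyl groups.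

The three compounds leave open whether both methyl groups of the 3,5-dimethylphenyl group are needed for the lower number, since a plain phenyl group and a phenyl group with a single methyl group do not appear among them. They also leave open whether the same step would appear with a shorter chain in place of the propyl linker or with a piperidine in place of the dimethylpiperidine at the end of that chain.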